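The source may hold more compounds than are shown below. What is called first, only, known or untested is meant among the compounds shown, and "the series" means these compounds.

Measured compounds:

Compound 1 `O=C(O)/C=C/c1ccncc1-c1ccc2ccccc2c1` — in a functional assay on HCT-116 cells (Homo sapiens) for inhibition, read by MTT assay, with a stated time of 72 h (on this read-out higher numbers stand for weaker inhibition of growth and lower numbers for stronger inhibition of growth), compound 1 gives > 30000 nM, which is a limit of the assay.
Compound 2 `O=C(/C=C/c1ccncc1-c1ccc2cc[nH]c2c1)N1CCOCC1` — in this assay compound 2 gives > 30000 nM, again a limit of the assay.
Compound 3 `O=C(/C=C/c1ccncc1-c1ccc2ccccc2c1)N1CCOCC1` — in this assay compound 3 gives 6040 nM.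

Compound 4 `O=C(O)/C=C/c1ccncc1-c1ccc2cc[nH]c2c1` has not been measured in this assay. Compound 4 relates to compound 2 by hydroxy in place of morpholin-4-yl on a carbonyl carbon, and compound 1 relates to compound 3 by the same change, (hydroxy in place of morpholin-4-yl on a carbonyl carbon); the "place" is worded identically for both, so this is the same change made twice. The difference between the cores of compound 2 and compound 3 is not broken down here.

In the measured pair the step is an at least 4.9-fold higher number from compound 3 to compound 1 (0.69 log units; beyond the scatter); its size beyond the lower-numbered end is open because of the limit of > 30000 nM in this assay, at which 2 of the 3 values shown sit. Compound 2 already sits at that limit, so the same change is expected to leave compound 4 at or past the limit as well, giving an expected step that the limit leaves unreadable from compound 2 to compound 4. Compound 4 is estimated at 70000 nM, with a range from 30000 nM to 300000 nM, and a number rather than a limit is not expected.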

Compound 4, concentration for 50% growth inhibition: > 30000 nM
Compound 4 gave a limit, no number; the forecaster's own chance of this, stated with the estimate: 90%; the middle value lies beyond the limit too.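

Compound 2 and compound 4 both stand at a limit in this assay, so no step can be read between them: the limit of > 30000 nM in this assay, at which 3 of the 4 values shown sit.

The compounds shown leave open whether hydroxy in place of morpholin-4-yl on a carbonyl carbon changes inhibition of growth at all on the core of compound 2.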